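Trading a Chlorobenzyl for an Aminoethyl Group

A few compounds are considered here, and "the series" means these few. Any claim that something is new, unique, unknown or untested is made for them only; others in the source may bear on it.

Compounds measured so far:
- compound 1, `O=c1c2ccccc2c(-c2cccnc2)nn1Cc1cccc(Cl)c1`: 95%
- compound 2, `O=c1c2ccccc2c(-c2cccnc2)nn1S(=O)(=O)c1ccccc1`: 96%

Both measured compounds were tested in an assay on isolated protein (Oryctolagus cuniculus) with Thromboxane-A synthase (Homo sapiens) as the target, tested at 1 uM; a higher number here means more inhibition at the concentration tested (going by the name of the read-out), a lower number less inhibition. Compound 1 gives 95% there, and compound 2 gives 96%; the two numbers sit within the usual scatter of each other, so neither compound can be set apart from the other on this evidence. Both show strong inhibition at the tested concentration.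

Compound 3, `NCCn1nc(-c2cccnc2)c2ccccc2c1=O`, has not yet been measured. It differs from compound 1 in one place: aminomethyl in place of 3-chlorophenyl on a saturated chain carbon bound to an aromatic nitrogen. Within the data shown here, no pair of measured compounds that differ in a single place exists here, so the size of this step cannot be read from any earlier one. Since the two measured compounds carry quite different groups on that aromatic nitrogen and still give similar high values, compound 3 is expected to keep much of the inhibition, with a modest drop allowed for: the step of a number 13 percentage points lower from compound 1 to compound 3 (beyond the scatter) is expected to be small to moderate and downward, possibly within the scatter. Compound 3 is estimated at 82%, within a range from 55% to 97%.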

Compound 3, a percentage reported as inhibition, at one concentration (the size of the read-out at that concentration, not a potency): 29%
Estimate against measurement, compound 3: 53 percentage points above; the whole stated range lies above it.
By their numbers in this assay, from the lowest: compound 3; then compounds 1 and 2 (each within the scatter of the next).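

In this assay, the step from 3-chlorobenzyl to 2-aminoethyl on the aromatic nitrogen is a number 66 percentage points lower from compound 1 to compound 3 (beyond the scatter), which shows that the group at this position can matter a great deal. This single change removes the six-membered aromatic ring and the chlorine and brings in a chain that ends in an amine, so the high inhibition of compound 1 does not carry over to compound 3. Nothing measured here explains the loss.

The compounds shown leave open whether the loss follows from removing the ring or from adding the amine, as both happen in this one step. A plain benzyl group without chlorine, a 2-hydroxyethyl chain or a longer 3-aminopropyl chain on the same nitrogen could help separate these two changes.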